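The source may report more compounds than this note shows. Statements on the series, on what has been measured and on what is new or still open speak of the compounds shown alone.

Of the compounds shown here, three sharing one core have been measured in an assay on CHO cells for displacement of a labelled ligand from 5-hydroxytryptamine receptor 1B (Homo sapiens); a higher number here means a weaker inhibitor, a lower number a stronger inhibitor. Compound 1 `O=S(=O)(NCC1CCN(CCCc2c[nH]c3ccc(-n4cnnc4)cc23)CC1)c1ccccc1` gives 60 nM. Compound 2 `C[C@H](NCC1CCN(CCCc2c[nH]c3ccc(-n4cnnc4)cc23)CC1)c1ccccc1` gives 58 nM. Compound 3 `c1ccc2c(c1)CCC2NCC1CCN(CCCc2c[nH]c3ccc(-n4cnnc4)cc23)CC1` gives 25 nM, the lowest of the three numbers. The three differ only in the group carried on the amine nitrogen that hangs from the saturated ring. a 1.0-fold lower number from compound 1 to compound 2 (0.01 log units; within the scatter), a change within the scatter. a 2.4-fold lower number from compound 1 to compound 3 (0.38 log units; beyond the scatter) and a 2.3-fold lower number from compound 2 to compound 3 (0.37 log units; beyond the scatter), both modest steps beyond the scatter.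

Compound 4 `c1cncc(CNC2CCN(CCCc3c[nH]c4ccc(-n5cnnc5)cc34)CC2)c1` is not yet measured. Relative to compound 3 the change is ((pyridin-3-yl)methyl)amino in place of ((2,3-dihydro-1H-inden-1-yl)amino)methyl on a saturated ring carbon. This alters more than the group on the nitrogen: the nitrogen now sits directly on the saturated ring carbon, and a group with two rings gives way to one with a single aromatic ring that carries a nitrogen. Among the measured compounds shown here, none of the measured steps covers such a change of attachment; they show only that swapping the group on the nitrogen moved the number by modest amounts at most. For the measured compounds named here, because compound 3 gives 25 nM as the lowest number so far, and because the steps of a 2.4-fold lower number from compound 1 to compound 3 (0.38 log units; beyond the scatter) and a 2.3-fold lower number from compound 2 to compound 3 (0.37 log units; beyond the scatter) were modest, a modest rise is expected: a 2.4-fold higher number from compound 3 to compound 4 (0.38 log units; beyond the scatter). Compound 4 is therefore estimated at 60 nM, with a range from 20 nM to 200 nM.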

Compound 4, half-maximal inhibitory concentration: 140 nM
Compound 4: middle estimate off by 2.3-fold (0.37 log units), on the low side, within the range that was stated.
By their numbers in this assay, from the lowest: compound 3; then compounds 2 and 1 (each within the scatter of the next); then compound 4.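

In this assay, placing ((pyridin-3-yl)methyl)amino on the saturated ring carbon in place of ((2,3-dihydro-1H-inden-1-yl)amino)methyl gives a 5.6-fold higher number from compound 3 to compound 4 (0.75 log units; beyond the scatter), the largest step in this set, though still a modest one. The same kind of replacement gives a 2.4-fold higher number from compound 2 to compound 4 (0.38 log units; beyond the scatter) and a 2.3-fold higher number from compound 1 to compound 4 (0.37 log units; beyond the scatter), so compound 4 is the weakest of the four, and this position is less forgiving of a change that moves the nitrogen onto the ring carbon and alters its group than of a swap of the group on the nitrogen alone. Nothing shown here accounts for this rise.

Because the attachment point and the group change together in compound 4, the compounds shown leave open how much of the rise goes with each. A (2,3-dihydro-1H-inden-1-yl)amino group placed directly on the saturated ring carbon would address the attachment, and a benzylamino group there, with a plain phenyl ring, would address the nitrogen in the aromatic ring.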